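The source may report more compounds than this note shows. Statements on the series, on what has been measured and on what is new or still open speak of the compounds shown alone.

Compound 3 `CCCCN(C)c1nc(C(F)(F)F)ccc1CNC(=O)C(C)c1ccc(NS(C)(=O)=O)c(F)c1` gives the lowest number of the three in a functional assay on CHO-K1 cells for antagonist activity at transient receptor potential cation channel subfamily V member 1 (Homo sapiens), read by FLIPR (on this read-out higher numbers stand for weaker inhibition and lower numbers for stronger inhibition), at 21.3 nM; compound 1 `CCCCNc1nc(C(F)(F)F)ccc1CNC(=O)C(C)c1ccc(NS(C)(=O)=O)c(F)c1` gives 293 nM and compound 2 `CC(C(=O)NCc1ccc(C(F)(F)F)nc1Nc1ccccc1)c1ccc(NS(C)(=O)=O)c(F)c1` gives 1400 nM. Compound 4 `CC(C(=O)NCc1ccc(C(F)(F)F)nc1N1CCCC1)c1ccc(NS(C)(=O)=O)c(F)c1` differs from compound 3 in one place: pyrrolidin-1-yl in place of butyl(methyl)amino on an aromatic carbon. For the measured compounds named here, the steps that bear on this are a 14-fold lower number from compound 1 to compound 3 (1.14 log units; beyond the scatter), which shows how much a methyl on that nitrogen matters, and a 66-fold lower number from compound 2 to compound 3 (1.82 log units; beyond the scatter); both kept a nitrogen without hydrogen. Compound 4 keeps such a nitrogen but ties the chain into a ring and loses one carbon, so only a modest shift is expected, a 1.6-fold higher number from compound 3 to compound 4 (0.22 log units; within the scatter). Compound 4 is therefore estimated at 35 nM in this assay, between 10 nM and 120 nM.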

Compound 4, half-maximal inhibitory concentration: 211 nM
For compound 4 the middle estimate is 6.0-fold (0.78 log units) below the measured one, outside the stated range (above it).
By their numbers in this assay, from the lowest: compound 3; then compounds 4 and 1 (each within the scatter of the next); then compound 2.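

Replacing butyl(methyl)amino with pyrrolidin-1-yl is no minor swap at this position, giving a 9.9-fold higher number from compound 3 to compound 4 (1.00 log units; beyond the scatter). A nitrogen without hydrogen is therefore not enough on its own: compound 4 cannot be told apart from compound 1, which carries butylamino, at a 1.4-fold lower number from compound 1 to compound 4 (0.14 log units; within the scatter), yet the change from anilino still gives a 6.6-fold lower number from compound 2 to compound 4 (0.82 log units; beyond the scatter). Nothing available explains these steps. The compounds shown leave open whether the ring itself or the lost carbon matters. A piperidin-1-yl ring or an open diethylamino group could help separate the two.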